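A few compounds are considered here, and "the series" means these few. Any claim that something is new, unique, unknown or untested is made for them only; others in the source may bear on it.

Working notes on the series.

Three compounds carry numbers in a functional assay on HEK293 cells for positive allosteric modulation of metabotropic glutamate receptor 5 (Rattus norvegicus), read by fluorescence and calcium flux; on this read-out lower numbers stand for smaller maximal responses and higher numbers for larger maximal responses. Compound 1 `C[C@@H](NC(=O)c1ccc(C#CC2CC2)cn1)C(C)(C)O` gives 63.4%. Compound 2 `C[C@@H](NC(=O)c1nc(C#Cc2cccc(F)c2)cs1)C(C)(C)O` gives 62.1%. Compound 3 `C[C@H](NC(=O)c1ccc(C#Cc2cccc(F)c2)cn1)C(C)(C)C` gives 70.8%, the highest of the three numbers, yet its distances to compound 1 and to compound 2 both fall within the scatter, so no order among the three is established on this read-out.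

Compound 4 `CC(C)CNC(=O)c1ccc(C#Cc2cccc(F)c2)cn1` remains to be measured in this assay. It differs from compound 3 in one place: isobutyl in place of 1,2,2-trimethylpropyl on an amide-type nitrogen. Among the compounds with values here, no step between measured compounds of this kind is available, so the expectation rests on the spread of the three numbers alone, which covers a narrow band. A step beyond the scatter in either direction is not expected; the estimated step of a number 7.8 percentage points lower from compound 3 to compound 4 (within the scatter) is meant to sit within the scatter. In this assay compound 4 is expected to give about 63%, with a range from 46% to 80%.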

Compound 4, largest response reached (reported as efficacy), in percent of the reference or control that the assay uses: 58.2%
For compound 4 the middle estimate is 4.8 percentage points above the measured one; the range from low to high includes it.
By their numbers in this assay, from the lowest: compounds 4, 2, 1 and 3 (each within the scatter of the next, the first and the last beyond it).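

With the rest of the molecule held constant, the amide-type nitrogen substituent is the first position in the series shown to move the number in this assay beyond the scatter: replacing 1,2,2-trimethylpropyl with isobutyl gives the step (a number 12.6 percentage points lower from compound 3 to compound 4 (beyond the scatter)). This single change both shortens the substituent from 6 heavy atoms to 4 and removes its 1 defined stereocentre, so one pair cannot separate these two differences. No measurement shown accounts for the step.

Still open, from the compounds shown here alone, is whether the mirror-image form of the 1,2,2-trimethylpropyl group on the same nitrogen would keep the number of compound 3 or fall towards that of compound 4. Also open, going by these compounds, is how a cyclohexyl group, an n-hexyl chain or a group carrying an amine would read at this position.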